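Swapping One Aryl Group in a Cytotoxicity Series

This account rests on a few compounds, and the source may have more. Where it says the series, first, only, none or still open, it means among the compounds named here.

Measured compounds:
Compound 1, `C=CCn1c(=O)/c(=C\c2ccccc2Cl)[nH]c(=O)/c1=C\c1ccccc1OC`: 4200 nM
Compound 2, `C=CCn1c(=O)/c(=C\c2ccc(C)cc2)[nH]c(=O)/c1=C\c1ccccc1OC`: "not active" (no number reported), with no number given.

Both measured compounds were run in a functional assay on HL-60 cells (Homo sapiens) for cytotoxicity, read by CCK-8 assay, with a stated time of 72 h; on this read-out higher numbers stand for weaker inhibition and lower numbers for stronger inhibition. For the measured compounds named here, compound 1 gives 4200 nM, and this is the only number among the compounds examined; compound 2 gives "not active" (no number reported) without a figure, so nothing can be said about the size of the gap between them beyond the fact that one compound shows measurable activity and the other does not. Compound 3, `C=CCn1c(=O)/c(=C\c2cc(F)ccc2C)[nH]c(=O)/c1=C\c1ccccc1OC`, has not yet been measured. It differs from compound 1 in a single place: 5-fluoro-2-methylphenyl in place of 2-chlorophenyl on a double-bonded chain carbon bound to an aromatic carbon.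

Going by the values given here, no measured pair separated by one change is available, so the size of this step cannot be anchored to an observed step. The expected step, a 1.9-fold higher number from compound 1 to compound 3 (0.28 log units; within the scatter), is a small loss, about at the edge of the usual scatter, given that a different aryl group in compound 2 removed measurable activity altogether. Compound 3 is therefore expected to give 8000 nM in this assay, within a range from 2500 nM to 30000 nM.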

Compound 3, half-maximal inhibitory concentration: 2600 nM
Beside the measured number, compound 3's estimate is 3.1-fold (0.49 log units) above it; the range from low to high includes it.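

In this assay the exchange of 2-chlorophenyl for 5-fluoro-2-methylphenyl on a double-bonded chain carbon bound to an aromatic carbon gives a 1.6-fold lower number from compound 1 to compound 3 (0.21 log units; within the scatter) and stays within the usual scatter, so compound 1 and compound 3 cannot be told apart on this read-out. This is the first comparison with a number on both sides, and it shows that measurable activity at this position survives a change of aryl group, including the loss of chlorine and the arrival of both fluorine and methyl, whereas compound 2 had shown only that another aryl group there can come with no reported number. No measured information is available to explain why this exchange leaves the value so little altered.

Since fluorine and methyl enter together, the compounds shown do not separate what each contributes, and 2-methylphenyl or 3-fluorophenyl would be needed to do so. On these data alone, it also remains open whether activity would persist with an aryl group carrying an amine or a carboxylic acid at this position, or with a non-aromatic group such as cyclohexyl in place of the aryl ring.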